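The compounds below may be only part of what the source reports. "The series", "measured", "known", "first", "only" and "open" are said of these compounds alone.

Three compounds were measured in a functional assay on KB cells (Homo sapiens) for cytotoxicity; on this read-out higher numbers stand for an effect only at larger amounts of compound and lower numbers for an effect already at smaller amounts. Compound 1 `COc1cc(C)cc2c1OC(c1ccccc1)CC2=O` gives 26 ug/mL in this assay. Compound 2 `COc1ccc(OC)c(-c2cc(=O)c3c(OC)c(OC)c(OC)c(OC)c3o2)c1` gives 4 ug/mL. Compound 3 `O=c1cc(-c2ccc(O)cc2)oc2c(O)c(O)c(O)cc12` gives 22 ug/mL. Among these three, compound 2 stands lowest: its gap to compound 3, the nearest, and its gap to compound 1, the furthest, both lie beyond the usual scatter of this assay, so compound 2 is the most potent of the set.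

Compound 4 `COc1cc(OC)c(-c2cc(=O)c3c(OC)c(OC)c(OC)c(OC)c3o2)cc1OC` has not been measured in this assay. It differs from compound 2 in one place: methoxy in place of hydrogen on an aromatic carbon. Among the compounds with values here, no measured pair in the set shows this change on its own, so the size of the step is not known from the data. The expectation is that the step from compound 2 to compound 4 a 1.3-fold higher number from compound 2 to compound 4 (0.10 log units; within the scatter) will be small, with no clear direction, and most likely within the scatter. On this basis compound 4 is estimated to give 5 ug/mL in this assay, with a range from 2 ug/mL to 12 ug/mL.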

Compound 4, concentration for half-maximal effect: 13 ug/mL
Compound 4: the middle estimate sits 2.6-fold (0.41 log units) below what was measured; measured number outside the range, above it.
By their numbers in this assay, from the lowest: compound 2; then compounds 4, 3 and 1 (each within the scatter of the next).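

In this assay, methoxy in place of hydrogen on an aromatic carbon, para to a large group, gives a 3.3-fold higher number from compound 2 to compound 4 (0.51 log units; beyond the scatter). Within the data shown here, this is the only single-place step in the set, and it shows that this position is not indifferent to the change: the added methoxy moves the number upward, towards an effect only at larger amounts of compound, though the step is modest. Nothing available accounts for this shift.

The compounds shown leave open whether the step belongs to methoxy itself or to any group on this carbon, as none of them carries a hydroxy group, a fluorine or an amine there on the core of compound 2. Also open, from the compounds shown here alone, is whether a longer chain, such as ethoxy, in the same place would move the number further in the same direction.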